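The source may report more compounds than this note shows. Statements on the series, on what has been measured and on what is new or still open speak of the compounds shown alone.

Two compounds have been measured so far in a physicochemical assay for solubility, read by HPLC, in phosphate buffer, measured as kinetic solubility, at pH 7.4 (a lower number here means a less soluble compound, a higher number a more soluble compound), and they read as follows
compound 1 `CCOC(=O)c1cc(-c2ccc(F)cc2)n(-c2ccc(S(N)(=O)=O)cc2)c1C` gives 12600 nM
compound 2 `CC(C)(C)C(=O)c1cc(-c2ccc(S(N)(=O)=O)cc2)n(-c2ccc(Cl)cc2)n1` gives 6600 nM

With compound 2 at 6600 nM and compound 1 at 12600 nM the two numbers lie within the usual scatter of each other, so they set no order. Compound 3 `NS(=O)(=O)c1ccc(-c2cc(C(=O)CC3CCC3)nn2-c2ccc(Cl)cc2)cc1` differs from compound 2 in one place, with cyclobutylmethyl in place of tert-butyl on a carbonyl carbon, and the counted change is cyclobutylmethyl in place of tert-butyl on a carbonyl carbon in full. Among the measured compounds shown here, no measured pair shows a change of this kind, so the data offer no direct guide. The starting point is compound 2 at 6600 nM and the expectation is a modest step toward a lower number in this assay that may not clear the scatter. The expected change is a 1.5-fold lower number from compound 2 to compound 3 (0.17 log units; within the scatter) in size. For compound 3 the estimated value is 4500 nM with an expected range from 1500 nM to 13000 nM in the measurement to come.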

Compound 3, solubility: 4300 nM
The estimate for compound 3 lay 1.0-fold (0.02 log units) above the measured number; measured number inside the range.
By their numbers in this assay, from the lowest: compounds 3, 2 and 1 (each within the scatter of the next, the first and the last beyond it).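

In this assay, putting cyclobutylmethyl in place of tert-butyl on a carbonyl carbon gives a 1.5-fold lower number from compound 2 to compound 3 (0.19 log units; within the scatter). Among the compounds shown here, this is the first pair here that differs in one place, and it shows that this position accepts a group with a four-membered non-aromatic ring of carbon only, instead of one with no ring, without a step that clears the scatter. No measured information on either group is available to explain the step.

From the compounds shown here alone, both groups are made of carbon only and carry no hydrogen-bond donors or acceptors, so the response at this carbonyl carbon to a group that has them, such as an amine or a carboxylic acid, remains open. Also open, going by these compounds, is whether a longer chain there would stay within the scatter of compound 2.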